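Replacing 4-fluorophenyl with pyrimidin-2-yl in an antiproliferative series

A few compounds are considered here, and "the series" means these few. Any claim that something is new, unique, unknown or untested is made for them only; others in the source may bear on it.

This account concerns a functional assay on HeLa cells (Homo sapiens) for antiproliferative activity, read by MTT assay, with a stated time of 72 h (a lower number here means a stronger inhibitor, a higher number a weaker inhibitor), and two compounds with a shared core. For compound 1 (`Cc1ccccc1N1CCN(C(=S)SCc2ccc3nc(N)nc(N)c3c2)CC1`) the entry reads "not determined" (no result reported) and supplies no number. Going by the values given here, compound 2 (`Nc1nc(N)c2cc(CSC(=S)N3CCN(c4ccc(F)cc4)CC3)ccc2n1`) gives 1840 nM as the only number available, so it cannot yet be ranked against any other compound.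

Compound 3 (`Nc1nc(N)c2cc(CSC(=S)N3CCN(c4ncccn4)CC3)ccc2n1`) keeps the shared core and carries pyrimidin-2-yl in place of 4-fluorophenyl on an amine nitrogen in a ring and its result is still outstanding. Among the compounds with values here, no measured pair shows what this replacement does in this assay so any forecast must remain loose. Within the data shown here, the only anchor is compound 2 at 1840 nM and nothing available argues for a move in either direction, so no change beyond the usual scatter is expected. The expected step is a 1.2-fold higher number from compound 2 to compound 3 (0.08 log units; within the scatter) and it stays within that scatter. For compound 3 the estimated value is 2200 nM with an expected range from 700 nM to 7000 nM on repeated measurement.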

Compound 3, half-maximal inhibitory concentration: 4360 nM
The estimate for compound 3 lay 2.0-fold (0.30 log units) below the measured number, within the range that was stated.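

In this assay, going by these compounds alone, this is the first measured reading of any change on the amine nitrogen in a ring: pyrimidin-2-yl in place of 4-fluorophenyl gives a 2.4-fold higher number from compound 2 to compound 3 (0.37 log units; beyond the scatter) and so moves the result modestly but beyond the scatter. The position therefore does not accept every aromatic ring alike, which compound 2 alone could not show and compound 1, with no number, could not help to show. The change swaps a ring of carbon only, carrying fluorine and with no hydrogen-bond acceptors, for a ring with 2 hetero atoms and 2 hydrogen-bond acceptors, but nothing at hand tells which part of that swap matters.

This single pair gives one step at one position, so it sets no trend, and whether the higher number follows the ring nitrogens or the loss of fluorine remains unresolved. An unsubstituted phenyl or a pyridin-2-yl on the same nitrogen would separate those two readings, and a non-aromatic group such as an acetyl would show whether an aromatic ring is needed there at all.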